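Methoxy in Place of Chloro: Expectations for Compound 4

The source may report more compounds than this note shows. Statements on the series, on what has been measured and on what is new or still open speak of the compounds shown alone.

Compound 1 `CC1(C)[C@H]2CC[C@]1(C)N(Cc1cn(-c3cccc(Cl)c3)nn1)C(=O)C2` belongs to a set of three close relatives that share one core and differ only in the group carried on an aromatic nitrogen. In a functional assay on OVCAR-3 cells (Homo sapiens) for inhibition, read by MTT assay, with a stated time of 24 h (a lower number here means a stronger inhibitor, a higher number a weaker inhibitor), compound 1 gives 50 nM. Compound 2 `CC1(C)[C@H]2CC[C@]1(C)N(Cc1cn(-c3ccccc3O)nn1)C(=O)C2` gives 90 nM in this assay, and compound 3 `Cc1ccc(-n2cc(CN3C(=O)C[C@@H]4CC[C@@]3(C)C4(C)C)nn2)cc1` gives 40 nM. Compound 1 therefore stands second highest of the three numbers, with a 1.3-fold lower number from compound 1 to compound 3 (0.10 log units; within the scatter) and a 1.8-fold higher number from compound 1 to compound 2 (0.26 log units; within the scatter), both within the scatter; only a 2.3-fold lower number from compound 2 to compound 3 (0.35 log units; beyond the scatter) reaches beyond it.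

Compound 4 `COc1cccc(-n2cc(CN3C(=O)C[C@@H]4CC[C@@]3(C)C4(C)C)nn2)c1` has not yet been measured. It departs from compound 1 by methoxy in place of chloro on an aromatic carbon. The measured steps that bear on this change are the other exchanges of the group on the aromatic nitrogen, a 1.8-fold higher number from compound 1 to compound 2 (0.26 log units; within the scatter) and a 1.3-fold lower number from compound 1 to compound 3 (0.10 log units; within the scatter), neither of which moved the number beyond the scatter. On that basis compound 4 is expected to stay close to compound 1 in this assay, and the estimated step is a 1.2-fold higher number from compound 1 to compound 4 (0.08 log units; within the scatter). The estimate for compound 4 in this assay is 60 nM, with an expected range from 25 nM to 150 nM.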

Compound 4, half-maximal inhibitory concentration: 280 nM
The estimate for compound 4 lay 4.7-fold (0.67 log units) below the measured number, and the stated range ends below it.
By their numbers in this assay, from the lowest: compounds 3, 1 and 2 (each within the scatter of the next, the first and the last beyond it); then compound 4.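

Replacing chloro with methoxy on an aromatic carbon, meta to a large group, gives a 5.6-fold higher number from compound 1 to compound 4 (0.75 log units; beyond the scatter) in this assay, so a small exchange at this place moved the number beyond the scatter, which neither earlier step away from compound 1 had done. The other two comparisons point the same way, with a 7.0-fold higher number from compound 3 to compound 4 (0.85 log units; beyond the scatter) and a 3.1-fold higher number from compound 2 to compound 4 (0.49 log units; beyond the scatter), showing that the close agreement among the first three compounds does not extend to every substituted phenyl group on the aromatic nitrogen. No measurement is available to explain why the number rose at this change.

Going by these compounds, with only chloro and methoxy compared at this place, it remains open whether the higher number is particular to methoxy or would also appear with an ethoxy group, an amine or a carboxylic acid there. The compounds shown also leave open whether methoxy on another carbon of the same ring would give a similar number, as the only methoxy shown sits meta to a large group.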